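The compounds below may be only part of what the source reports. "The series", "measured", "known", "first", "only" and "open" are said of these compounds alone.

Compound 1 `CC1=CC[C@@H]([C@@](C)(O)CCCC(C)(C)NC(=S)NN)CC1` is a thiosemicarbazide built on a hydroxylated cyclohexenyl core. In a functional assay on K562 cells (Homo sapiens) for cytotoxicity, read by sulforhodamine B assay (a higher number here means a weaker inhibitor of growth, a lower number a stronger inhibitor of growth), compound 1 gives 380 nM, the lowest of the two numbers measured here. Among the measured compounds shown here, its only neighbour in this set is compound 2 `COc1ccc(/C=N\NC(=S)NC(C)(C)CCC[C@](C)(O)[C@@H]2CC=C(C)CC2)cc1`, where the terminal amino nitrogen has been condensed with an aromatic aldehyde; in this assay compound 2 gives 34900 nM, a 92-fold higher number from compound 1 to compound 2 (1.96 log units; beyond the scatter).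

Compound 3 `CC1=CC[C@@H]([C@@](C)(O)CCCC(C)(C)NC(=S)N/N=C\c2cccc(Cl)c2)CC1` is reached from compound 1 by a change of the same kind: a group of 9 heavy atoms (7 carbon, 1 nitrogen, 1 chlorine; one six-membered aromatic ring of carbon only) in place of one nitrogen atom, on an amide-type nitrogen. For the measured compounds named here, the only measured step that bears on this change is the one from compound 1 to compound 2, which was large and in the direction of a weaker inhibitor of growth. A similarly large rise is therefore expected here, and compound 3 is expected to show a 66-fold higher number from compound 1 to compound 3 (1.82 log units; beyond the scatter). The estimate for compound 3 in this assay is 25000 nM, with a range from 7000 nM to 90000 nM.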

Compound 3, concentration for total growth inhibition: 1060 nM
Estimate against measurement, compound 3: 24-fold (1.37 log units) above; the whole stated range lies above it.
By their numbers in this assay, from the lowest: compound 1; then compound 3; then compound 2.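

Attaching an aromatic ring at this nitrogen does not always bring a large loss: the 3-chlorophenyl group costs far less (a 2.8-fold higher number from compound 1 to compound 3 (0.45 log units; beyond the scatter)) than the earlier step suggested. The outcome depends strongly on the ring's substituent, since with the rest of the molecule unchanged, 3-chlorophenyl in place of 4-methoxyphenyl gives a large change (a 33-fold lower number from compound 2 to compound 3 (1.52 log units; beyond the scatter)) in this assay. Even so, compound 1, with its free amino group, keeps the lowest number of the three.

Nothing measured here explains the gap between the two aromatic groups. Since the substituent and its place on the ring change together, a 4-chlorophenyl or 3-methoxyphenyl group would be needed to separate the two, and an unsubstituted phenyl group would show what the bare ring does.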